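The source may report more compounds than this note shows. Statements on the series, on what has been measured and on what is new or still open speak of the compounds shown alone.

The study concerns inhibition of an enzyme from mouse brain, followed in an assay on membranes from brain for binding affinity to Fatty-acid amide hydrolase 1 (Mus musculus), read by fluorescence, with stated times of 1 h and 30 min; a lower number here means a stronger inhibitor, a higher number a weaker inhibitor. Compound 1 `O=C(N1CCCN(Cc2ccc(OCc3ccccc3)cc2)CC1)n1cccn1` and compound 2 `N#Cc1cnn(C(=O)N2CCCN(Cc3ccc(OCc4ccccc4)cc3)CC2)c1` share one core; compound 2 differs from compound 1 only in that it carries cyano in place of hydrogen on an aromatic carbon. In this assay compound 1 gives 450 nM. For compound 2 this assay reports no number but only a limit, < 10 nM, and the limit of < 10 nM in this assay, at which 1 of the 3 values shown sits, records that one of the values shown sits at it. Going by these compounds, the change therefore produced an at least 45-fold lower number from compound 1 to compound 2 (1.65 log units; beyond the scatter), and because the limit of < 10 nM in this assay, at which 1 of the 3 values shown sits, is a limit the full size of that step remains unknown.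

Compound 3 `CN(CCN(C)C(=O)n1cccn1)Cc1cccc(OCc2ccccc2)c1` is built on a different core; the difference between the two cores is not broken down here. In this assay compound 3 gives 3000 nM, the highest of the two numbers, a higher value than compound 1 shows. Compound 4 `CN(CCN(C)C(=O)n1cc(C#N)cn1)Cc1cccc(OCc2ccccc2)c1` has not yet been measured in this assay. It differs from compound 3 by cyano in place of hydrogen on an aromatic carbon, the same change, at the same place, as that between compound 1 and compound 2.

Given that the earlier instance gave an at least 45-fold lower number from compound 1 to compound 2 (1.65 log units; beyond the scatter), the step from compound 3 to compound 4 is expected to be a 50-fold lower number from compound 3 to compound 4 (1.70 log units; beyond the scatter), with the caveat that the earlier step is known only as a lower bound. Compound 4 is accordingly estimated at about 60 nM, with a likely range from 10 nM to 300 nM.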

Compound 4, half-maximal inhibitory concentration: 190 nM
For compound 4 the middle estimate is 3.2-fold (0.50 log units) below the measured one, and the stated range covers the measured number.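

Carried onto the core of compound 3, the change from 1H-pyrazol-1-yl to 4-cyano-1H-pyrazol-1-yl again lowers the number in this assay, with a 16-fold lower number from compound 3 to compound 4 (1.20 log units; beyond the scatter), so the direction of the step holds on the two cores shown, and two pairs of compounds can support no wider claim than that. The size of the step does not carry over unchanged, and the step on the core of compound 3 is the smaller of the two: the same change on two cores in this assay, an at least 45-fold lower number (1.65 log units; beyond the scatter) from compound 1 to compound 2 and a 16-fold lower number (1.20 log units; beyond the scatter) from compound 3 to compound 4, at least 2.8-fold (0.45 log units) apart, beyond the scatter of two such steps. Going by these compounds, how far apart the two steps really stand remains unknown, since the value of compound 2 is a limit and the earlier step therefore has no known upper end: the limit of < 10 nM in this assay, at which 1 of the 4 values shown sits.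

The compounds shown leave open whether another group on the same aromatic carbon, such as an amine, a carboxylic acid or a methyl ester, would lower the number in this assay as cyano does on either core. Among the compounds shown here, they also leave open whether the cyano step would keep its direction, or shrink further, on a core with a longer chain in place of the one in compound 3.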